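Triazole hydroxamates: ethenyl linker in place of phenyl

This account rests on a few compounds, and the source may have more. Where it says the series, first, only, none or still open, it means among the compounds named here.

Compound 1 `O=C(/C=C/c1cn([C@@H]2C[C@H](CO)N(CCCc3ccccc3)C2)nn1)NO` gives 12% in an assay on Sf9 cells for inhibition of histone deacetylase 11 (Homo sapiens), read by fluorescence, tested at 0.5 uM; a lower number here means less inhibition, a higher number more inhibition at the concentration tested (going by the name of the read-out). Compound 2 `O=C(NO)c1cccc(-c2cn([C@@H]3C[C@@H](CO)N(CCCc4ccccc4)C3)nn2)c1` is reported in this assay only as a limit, < 10%, which is the limit of < 10% in this assay, at which 1 of the 2 values shown sits. Compound 2 thus stands at the bottom of the two numbers shown, with no figure of its own. Compound 3 `O=C(/C=C/c1cn([C@@H]2C[C@@H](CO)N(CCCc3ccccc3)C2)nn1)NO` is not yet tested in this assay. It differs from compound 2 in one place: 2-(hydroxycarbamoyl)ethenyl in place of 3-(hydroxycarbamoyl)phenyl on an aromatic carbon. Among the measured compounds shown here, no measured step joins a pair of this kind, so no size is fixed for it. As compound 2 gives only a limit, a step beyond the scatter could only run upward. Compound 1 at 12% gives no ground to expect a large one in this assay. Compound 3 is expected to give 11%, within 4% to 20%. The implied step a number at least 1 percentage points higher from compound 2 to compound 3 (that floor lies within the scatter) is expected to stay within the usual scatter.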

Compound 3, a percentage reported as inhibition, at one concentration (the size of the read-out at that concentration, not a potency): 13%
For compound 3 the middle estimate is 2 percentage points below the measured one; low and high end bracket the measured number.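

Compound 2 is held only as a limit of the assay: < 10% and no figure of its own. In this assay, 2-(hydroxycarbamoyl)ethenyl in place of 3-(hydroxycarbamoyl)phenyl on the aromatic carbon gives a number at least 3 percentage points higher from compound 2 to compound 3 (that floor lies within the scatter) and so fixes a floor, not a size: the limit of < 10% in this assay, at which 1 of the 3 values shown sits. The pair with the saturated ring stereocentre drawn R in compound 1 and S in compound 3 shows a number 1 percentage points higher from compound 1 to compound 3 (within the scatter) and thus no readable effect of that stereocentre on the ethenyl series at this concentration: the fact that compounds 1 and 3 differ only in the configuration as drawn.

Open, as far as these compounds go, is whether a carboxylic acid in place of the hydroxycarbamoyl end, or a longer chain leading to it from the aromatic carbon, would give a read-out beyond the scatter of these values. With a single tested concentration, no potency can be stated for any of the three compounds.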